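A few compounds are considered here, and "the series" means these few. Any claim that something is new, unique, unknown or untested is made for them only; others in the source may bear on it.

Compound 3 `CS(=O)(=O)N1CCN(CC(O)CN2CCC(CNC(=O)c3cccc4[nH]c(C5CC5)nc34)CC2)CC1` is the starting point. In a functional assay for agonist activity at 5-hydroxytryptamine receptor 4 (Homo sapiens), read by cAMP accumulation (on this read-out lower numbers stand for smaller maximal responses and higher numbers for larger maximal responses), compound 3 gives 64%. Two further compounds frame this number. Compound 1 `CC(=O)N1CCN(CCN2CCC(CNC(=O)c3cccc4[nH]c(C(C)C)nc34)CC2)CC1` gives 76% in this assay, and compound 2 `CC(=O)N(C)CC(O)CN1CCC(CNC(=O)c2cccc3[nH]c(C(C)C)nc23)CC1` gives 64%. Among the compounds with values here, the one single-site step among the measured compounds is a number 12 percentage points lower from compound 1 to compound 2 (beyond the scatter), a change that concerns the chain on the ring amine nitrogen, far from the aromatic part of the core. Compound 3 reads the same as compound 2 at the digits recorded, and both stand beneath compound 1 by a margin beyond the usual scatter.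

The next compound, compound 4 `CCc1nc2c(C(=O)NCC3CCN(CC(O)CN4CCN(S(C)(=O)=O)CC4)CC3)cccc2[nH]1`, differs from compound 3 only on the aromatic core: ethyl in place of cyclopropyl on an aromatic carbon. Within the data shown here, no measured step touches that position. Among the measured compounds shown here, the only step recorded concerns a different part of the molecule, so it offers no direct guidance on what a small alkyl for a small ring at this aromatic carbon does in this assay. Compound 4 is therefore expected to behave like compound 3, with a step of a number 2 percentage points lower from compound 3 to compound 4 (within the scatter) that stays within the scatter. The estimate for compound 4 is 62%, with a range from 50% to 74%.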

Compound 4, intrinsic activity: the largest response reached, in percent of the reference agonist's: 22%
Compound 4: the middle estimate sits 40 percentage points above what was measured; the measured number lies below the stated range.
By their numbers in this assay, from the lowest: compound 4; then compounds 2 and 3 (each within the scatter of the next); then compound 1.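

In this assay, ethyl in place of cyclopropyl gives a number 42 percentage points lower from compound 3 to compound 4 (beyond the scatter), which shows that this aromatic carbon between two ring nitrogen atoms has a large bearing on the maximal response, a matter on which the earlier step, confined to the chain on the ring amine nitrogen, was silent. The change itself is small on paper: a three-membered ring of carbon only, with 3 heavy atoms, gives way to an open group of 2 heavy atoms, with no hydrogen-bond donors, acceptors or net charge on either side, so the read-out at this position responds strongly to a difference confined to carbon. Nothing at hand gives a reason for the size of this step.

Compounds 1 and 2 carry isopropyl at this carbon but differ from compound 4 in the chain as well, so they cannot be set directly against it, and a single pair cannot tell whether the ring of compound 3 or the ethyl of compound 4 sets the result. On these data alone, how a cyclobutyl ring, a methyl group or a longer chain such as propyl would behave at this carbon remains open.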